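The compounds below may be only part of what the source reports. "The series", "measured", "known", "first", "only" and "open" are said of these compounds alone.

Three compounds share one core and differ only in the group carried on a saturated chain carbon bound to a saturated ring carbon. Compound 1 `CCN1CCN(C[C@H]2CN(c3ccc(-n4cc(-c5ccccn5)cn4)c(F)c3)C(=O)O2)CC1` gives 2.19 in a physicochemical assay for lipophilicity, read by HPLC, measured as octanol-water partition; on this read-out lower numbers stand for lower lipophilicity and higher numbers for higher lipophilicity. Compound 2 `O=C1O[C@@H](CN2CCCCC2)CN1c1ccc(-n2cc(-c3ccccn3)cn2)c(F)c1` gives 3.1, and compound 3 `COC(=O)CC1CCN(C[C@H]2CN(c3ccc(-n4cc(-c5ccccn5)cn4)c(F)c3)C(=O)O2)CC1` gives 1.78. Compound 3 thus stands lowest of the three numbers, with compound 1 nearest and compound 2 furthest. The measured steps were a number 0.91 log units higher from compound 1 to compound 2 (beyond the scatter), a number 0.41 log units lower from compound 1 to compound 3 (beyond the scatter) and a number 1.32 log units lower from compound 2 to compound 3 (beyond the scatter). Compound 4 `O=C1CNC(=O)N1C[C@H]1CN(c2ccc(-n3cc(-c4ccccn4)cn3)c(F)c2)C(=O)O1` has not yet been measured. Its change from compound 3 is 2,5-dioxoimidazolidin-1-yl in place of 4-((methoxycarbonyl)methyl)piperidin-1-yl on a saturated chain carbon bound to a saturated ring carbon. For the measured compounds named here, none of the measured steps exchanges the whole ring at this place, so they bear on it only loosely; the largest of them, a number 1.32 log units lower from compound 2 to compound 3 (beyond the scatter), shows how far one change there can move this assay. For compound 4 the expected step is a number 0.58 log units lower from compound 3 to compound 4 (beyond the scatter), a drop beyond the scatter. Compound 4 is therefore estimated at 1.2, within a range from 0.6 to 1.8.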

Compound 4, partition coefficient: 1.25
Compound 4: the middle estimate sits 0.05 log units below what was measured, within the range that was stated.
By their numbers in this assay, from the lowest: compound 4; then compound 3; then compound 1; then compound 2.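

In this assay, exchanging the whole group at this place for 2,5-dioxoimidazolidin-1-yl gives a number 0.53 log units lower from compound 3 to compound 4 (beyond the scatter) and a number 0.94 log units lower from compound 1 to compound 4 (beyond the scatter) and also a number 1.85 log units lower from compound 2 to compound 4 (beyond the scatter) on the same shared core. The low end of this series therefore lies beyond what the 4-((methoxycarbonyl)methyl)piperidin-1-yl group reached, and compound 4 now stands lowest of the four. The entering five-membered ring has fewer heavy atoms than the six-membered ring group it replaces and adds a hydrogen-bond donor, but these differences arrive together, and no measurement here explains the drop.

Still open, on these data alone, is how much depends on the amide hydrogen, which a methyl group on that ring nitrogen would test. An open-chain acetamide at the same place would show whether the ring itself matters.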